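Aryl substituent series: methylsulfanyl to bromo

The source may report more compounds than this note shows. Statements on the series, on what has been measured and on what is new or still open speak of the compounds shown alone.

Measured in a functional assay on KBVIN cells (Homo sapiens) for antiproliferative activity, read by sulforhodamine B assay, with a stated time of 3 days; a higher number here means that more compound is needed for the effect, a lower number that less compound is needed:
- compound 1 `CCC1=C(O)c2c(oc(-c3ccc(C)cc3)cc2=O)C(CC)(CC)C1=O`: 0.08 uM
- compound 2 `CCC1=C(O)c2c(oc(-c3ccc(C(F)(F)F)cc3)cc2=O)C(CC)(CC)C1=O`: 10.4 uM
- compound 3 `CCC1=C(O)c2c(oc(-c3ccc(SC)cc3)cc2=O)C(CC)(CC)C1=O`: 1.38 uM

Compound 3 holds the middle place among the three numbers, with a 17-fold higher number from compound 1 to compound 3 (1.24 log units; beyond the scatter) on one side and a 7.5-fold lower number from compound 2 to compound 3 (0.88 log units; beyond the scatter) on the other, both beyond the scatter.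

The next structure is compound 4 `CCC1=C(O)c2c(oc(-c3ccc(Br)cc3)cc2=O)C(CC)(CC)C1=O`, with bromo in place of methylsulfanyl on an aromatic carbon. The change is bromo in place of methylsulfanyl on an aromatic carbon, para to a large group.

Among the compounds with values here, no measured step involves bromo, so the evidence is indirect. Leaving methyl gave large steps, a 130-fold higher number from compound 1 to compound 2 (2.11 log units; beyond the scatter) and a 17-fold higher number from compound 1 to compound 3 (1.24 log units; beyond the scatter), but compound 4 does not start from methyl. Within the data shown here, the closest precedent is the exchange between two non-methyl groups, a 7.5-fold lower number from compound 2 to compound 3 (0.88 log units; beyond the scatter), which was modest. In this assay, a step of at most that size is therefore expected, with no firm direction and possibly none beyond the scatter.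

The estimated step is a 1.4-fold higher number from compound 3 to compound 4 (0.16 log units; within the scatter). For compound 4 the estimated value is 2 uM, with an expected range from 0.4 uM to 10 uM.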

Compound 4, concentration for half-maximal effect: 15.7 uM
Beside the measured number, compound 4's estimate is 7.9-fold (0.89 log units) below it; the whole stated range lies below it.
By their numbers in this assay, from the lowest: compound 1; then compound 3; then compounds 2 and 4 (each within the scatter of the next).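

In this assay, the step of an 11-fold higher number from compound 3 to compound 4 (1.06 log units; beyond the scatter) shows that an exchange between two non-methyl groups at this place, para to a large group, can be large, and the step of a 200-fold higher number from compound 1 to compound 4 (2.29 log units; beyond the scatter) makes bromo the third replacement of methyl to raise the number beyond the scatter. With a 1.5-fold higher number from compound 2 to compound 4 (0.18 log units; within the scatter) as the step between them, bromo and trifluoromethyl are not separated here, while methylsulfanyl stands apart from both and methyl from all three. Nothing available accounts for these differences between the groups.

The compounds shown leave open how ethyl, methoxy or an amine at this place would compare, and so whether the low number of compound 1 is special to methyl. Also open, on these data alone, is whether the same ranking holds in any other cell line.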